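A few compounds are considered here, and "the series" means these few. Any claim that something is new, unique, unknown or untested is made for them only; others in the source may bear on it.

Measured so far in a functional assay on SK-BR-3 cells (Homo sapiens) for antiproliferative activity; a lower number here means a stronger inhibitor, a higher number a weaker inhibitor:

compound 1, `CCNCCCOc1ccc2cc(NC(=O)c3ccc(O)c(CC=C(C)C)c3)c(=O)oc2c1C`: 720 nM
compound 2, `COC(=O)CNCCCOc1ccc2cc(NC(=O)c3ccc(O)c(CC=C(C)C)c3)c(=O)oc2c1C`: 1060 nM
compound 3, `CC(C)=CCc1cc(C(=O)Nc2cc3ccc(OCCCNC4CCCCC4)c(C)c3oc2=O)ccc1O`: 660 nM

Compound 1 stands second highest of the three numbers in this assay; its nearest neighbour is compound 3 with a 1.1-fold lower number from compound 1 to compound 3 (0.04 log units; within the scatter), and its furthest is compound 2 with a 1.5-fold higher number from compound 1 to compound 2 (0.17 log units; within the scatter). Both steps lie within the scatter, as does a 1.6-fold lower number from compound 2 to compound 3 (0.21 log units; within the scatter), so the three amine substituents have so far left the read-out essentially unchanged.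

Compound 4, `CC(C)=CCc1cc(C(=O)Nc2cc3ccc(OCCCNC(C)(C)c4ccccc4)c(C)c3oc2=O)ccc1O`, is the next step from compound 1. The change is 1-methyl-1-phenylethyl in place of ethyl on an amine nitrogen. The step most closely related is the one in which cyclohexyl replaced ethyl on the same amine nitrogen, a 1.1-fold lower number from compound 1 to compound 3 (0.04 log units; within the scatter), which stayed within the scatter; the exchange of the amine substituent for (methoxycarbonyl)methyl, a 1.5-fold higher number from compound 1 to compound 2 (0.17 log units; within the scatter), did likewise. On that basis the expectation for compound 4 is a step no larger than the scatter, a 1.0-fold lower number from compound 1 to compound 4 (0.01 log units; within the scatter), in no firm direction. Compound 4 is therefore expected to give about 700 nM in this assay, estimated to lie between 350 nM and 1400 nM.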

Compound 4, half-maximal inhibitory concentration: 960 nM
Compound 4: middle estimate off by 1.4-fold (0.14 log units), on the low side; the measured number falls inside the stated range.
By their numbers in this assay, from the lowest: compounds 3, 1, 4 and 2 (each within the scatter of the next).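

The amine nitrogen accepts 1-methyl-1-phenylethyl, the first substituent here to carry an aromatic ring, with no change in this assay beyond the scatter, whether set against ethyl (a 1.3-fold higher number from compound 1 to compound 4 (0.12 log units; within the scatter)), cyclohexyl (a 1.5-fold higher number from compound 3 to compound 4 (0.16 log units; within the scatter)) or (methoxycarbonyl)methyl (a 1.1-fold lower number from compound 2 to compound 4 (0.04 log units; within the scatter)). The flat response at this position thus now extends to an aromatic substituent as well as to chain, ester-bearing and saturated ring groups. Nothing measured on these compounds explains this flat response.

The compounds shown leave open whether a carboxylic acid in place of the methyl ester, or a free primary amine with no substituent at all, would move the number beyond the scatter. Going by these compounds, it also remains open whether a longer chain between the core and the amine would do so.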